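Adding a Methyl Group to Compound 3: What to Expect

A few compounds are considered here, and "the series" means these few. Any claim that something is new, unique, unknown or untested is made for them only; others in the source may bear on it.

Compound 1 `O=C(Nc1nn[nH]n1)c1cccc(-c2ccccc2)n1` gives 74% in a functional assay on the whole organism with Rattus norvegicus as the target, at a dose of 3 mg/kg by the oral route; on this read-out lower numbers stand for a weaker effect and higher numbers for a stronger effect at the one dose given. Compound 2 `Cc1cc(C(=O)Nc2nn[nH]n2)nc(-c2ccccc2)c1` differs from compound 1 by methyl in place of hydrogen on an aromatic carbon, and in this assay compound 2 gives 50%. Compound 3 `CCCCc1cc(C(=O)Nc2nn[nH]n2)nc(-c2ccccc2)c1` differs from compound 1 by butyl in place of hydrogen on an aromatic carbon, and in this assay compound 3 gives 71%, a change of a number 3 percentage points lower from compound 1 to compound 3 (within the scatter).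

Compound 4 `CCCCc1cc(C(=O)Nc2nn[nH]n2)nc(-c2cccc(C)c2)c1` is not yet measured. It differs from compound 3 by methyl in place of hydrogen on an aromatic carbon. This is the same kind of change as from compound 1 to compound 2, not the same: there the place was a six-membered aromatic ring with one nitrogen, opposite the ring nitrogen; here it is a six-membered aromatic ring of carbon only, meta to a large group. That earlier step was a number 24 percentage points lower from compound 1 to compound 2 (beyond the scatter).

Among the compounds with values here, a step of a number 11 percentage points lower from compound 3 to compound 4 (beyond the scatter) is expected from compound 3 to compound 4, because the only comparable change gave a number 24 percentage points lower from compound 1 to compound 2 (beyond the scatter), though at a different place. Compound 4 is therefore estimated at 60%, between 40% and 80%.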

Compound 4, a percentage reported as inhibition, in the whole organism at one dose (the size of the read-out at that dose, not a potency): 82%
Compound 4: middle estimate off by 22 percentage points, on the low side; measured number above the stated range.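

In this assay, replacing phenyl with 3-methylphenyl gives a number 11 percentage points higher from compound 3 to compound 4 (beyond the scatter). Putting a methyl group in place of a hydrogen on an aromatic carbon therefore did not give the same result in the two cases, and the two steps run in opposite directions: the same change on two cores in this assay, a number 24 percentage points lower (beyond the scatter) from compound 1 to compound 2 and a number 11 percentage points higher (beyond the scatter) from compound 3 to compound 4, 35 percentage points apart, beyond the scatter of two such steps. This warns against carrying the earlier step over to a new core, but the two methyl groups also sit at different places, so these two pairs cannot separate the effect of the core from that of the place.

The compounds shown leave open how an ethyl group, a methoxy group or a chlorine atom would behave at the place taken by the methyl group in compound 4. They also leave open what 3-methylphenyl would do on the core of compound 1, without the butyl group.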